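Removing a Chlorine from a Weak Cell-Growth Inhibitor

This account rests on a few compounds, and the source may have more. Where it says the series, first, only, none or still open, it means among the compounds named here.

Of the compounds shown here, three built on one shared core have been tested in a functional assay on FM3A cells (Mus musculus) for inhibition, read by cell counting, with a stated time of 2 days; a lower number here means a stronger inhibitor, a higher number a weaker inhibitor. Compound 1 `Nc1cccc(-c2cn3c(-c4ccc(Cl)cc4)csc3n2)c1` gives 11000 nM, the highest number of the three. Compound 3 `COc1cccc(Cc2nn3cc(-c4cccc(N)c4)nc3s2)c1` gives 10000 nM, a number within the scatter of compound 1, so the two cannot be told apart. Compound 2 `C=C(Br)C(=O)Nc1cccc(-c2cn3nc(CCc4ccccc4)sc3n2)c1` gives 2600 nM, a lower number than compound 1 that lies beyond the scatter. Compound 4 `Nc1cccc(-c2cn3c(-c4ccccc4)csc3n2)c1` has not yet been measured. It differs from compound 1 in one place: hydrogen in place of chloro on an aromatic carbon. Among the measured compounds shown here, no measured pair shows this same change, so its size is unknown here. A step of no size beyond the scatter, or at most a slightly higher number, is expected, a 1.4-fold higher number from compound 1 to compound 4 (0.13 log units; within the scatter). Compound 4 is therefore estimated at 15000 nM, with a range from 6000 nM to 40000 nM.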

Compound 4, half-maximal inhibitory concentration: 34000 nM
Compound 4: the middle estimate sits 2.3-fold (0.36 log units) below what was measured; measured number inside the range.
By their numbers in this assay, from the lowest: compound 2; then compounds 3 and 1 (each within the scatter of the next); then compound 4.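

In this assay the change from 4-chlorophenyl to phenyl gives a 3.1-fold higher number from compound 1 to compound 4 (0.49 log units; beyond the scatter) and so weakens the inhibitor. Among the compounds shown here, this is the first pair in the set that differs in one place, and it shows that the activity responds to what sits on this aromatic carbon, with chloro better than hydrogen. Nothing available explains why the number moves. As far as these compounds go, whether a fluoro, methyl or amine group at this place would match or beat chloro remains open. So does whether losing the chloro costs as much on another core.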